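This account rests on a few compounds, and the source may have more. Where it says the series, first, only, none or still open, it means among the compounds named here.

Measured compounds:
Compound 1, `C/N=C(/NC#N)NCCCCCn1nc(-c2ccccc2)ccc1=O`, gives 47.6%.
Compound 2, `CC/N=C(/NC#N)NCCCn1nc(-c2ccccc2)ccc1=O`, gives 62.9%.
Compound 3, `CC/N=C(/NC#N)NCCCn1nc(C)ccc1=O`, gives 34.5%.

All three were tested in a functional assay on the whole organism with Rattus norvegicus as the target, at a dose of 100 mg/kg; a lower number here means less inhibition, a higher number more inhibition at the dose given (going by the name of the read-out). Compound 2 stands highest of the three, compound 1 second, and compound 3 lowest; each gap between them is beyond the scatter. The unmeasured compound 4, `C/N=C(/NC#N)NCCCCCn1nc(C)ccc1=O`, has not yet been tested in this assay.

From compound 2 to compound 3 the change is methyl in place of phenyl on an aromatic carbon, and it gave a number 28.4 percentage points lower from compound 2 to compound 3 (beyond the scatter). Compound 4 carries the same change relative to compound 1: methyl in place of phenyl on an aromatic carbon. The surroundings of the change are described in identical words for both pairs, so this is the same change, seen twice among the compounds shown. The cores of compound 1 and compound 2 differ in a way that is not broken down here.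

Among the compounds with values here, with only one measured example of the change, the expectation for compound 4 rests on that single pair. Within the data shown here, compound 4 is expected to show a number 27.6 percentage points lower from compound 1 to compound 4 (beyond the scatter), a step of about the size seen from compound 2 to compound 3, because a number 28.4 percentage points lower from compound 2 to compound 3 (beyond the scatter) is the only guide available. On this basis compound 4 is estimated at 20%, with a range of 5% to 38%, the wider range reflecting that a single pair may not transfer fully to a core that differs by the chain and the substituent pattern of compound 1.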

Compound 4, a percentage reported as inhibition, in the whole organism at one dose (the size of the read-out at that dose, not a potency): 14.9%
The estimate for compound 4 lay 5.1 percentage points above the measured number; low and high end bracket the measured number.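

In this assay, methyl in place of phenyl on an aromatic carbon, next to the ring nitrogen, again gave a lower number, with a number 32.7 percentage points lower from compound 1 to compound 4 (beyond the scatter). Set beside the earlier pair, the change carried across from one core to the other with a step of matching size: the same change on two cores in this assay, a number 28.4 percentage points lower (beyond the scatter) from compound 2 to compound 3 and a number 32.7 percentage points lower (beyond the scatter) from compound 1 to compound 4, 4.3 percentage points apart, within the scatter of two such steps. This shows that, within these two pairs, the loss on going from phenyl to methyl did not depend on which of the two cores carried it, but it does not show that the step would hold on a third core, it gives no potency, as each number comes from a single dose, and it does not tell why phenyl gives the higher number.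

The compounds shown leave open what an ethyl group, a cyclohexyl ring or a pyridine ring would give on that same aromatic carbon, and so whether the number follows the size of the group or needs an aromatic ring. Within the data shown here, they also leave open what a longer chain would do by itself, as no pair here differs in the chain alone.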